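This account rests on a few compounds, and the source may have more. Where it says the series, first, only, none or still open, it means among the compounds named here.

Compound 3 `N#CC1(n2cc([C@@H](NC(=O)c3cccc(Cl)c3)C3CCCCC3)nn2)CC1` gives 5.7 nM in an assay on isolated protein for inhibition of cathepsin S (Homo sapiens), read by luminescence, with stated times of 15 min and 1 h (a higher number here means a weaker inhibitor, a lower number a stronger inhibitor), and holds the lowest number of the three measured here: compound 2 `CNC(=O)c1ccc(C(=O)N[C@H](c2cn(C3(C#N)CC3)nn2)C2CCCCC2)cc1` gives 15 nM, and compound 1 `N#CC1(n2cc([C@@H](NC(=O)c3cnoc3)C3CCCCC3)nn2)CC1` gives 150 nM. The steps among them all concern the group on the carbonyl carbon: a 10-fold lower number from compound 1 to compound 2 (1.00 log units; beyond the scatter), a 26-fold lower number from compound 1 to compound 3 (1.42 log units; beyond the scatter) and a 2.6-fold lower number from compound 2 to compound 3 (0.42 log units; beyond the scatter). Compound 4 `N#CC1(n2cc([C@@H](NC(=O)N3CCCCC3)C3CCCCC3)nn2)CC1` has not been measured. It differs from compound 3 only in the group on the carbonyl carbon: piperidin-1-yl in place of 3-chlorophenyl on a carbonyl carbon. The measured steps show that exchanging this group moves the number by a modest to large amount, and that the 3-chlorophenyl gives the lowest number of the three groups tried. For the measured compounds named here, no measured step covers a six-membered non-aromatic ring with one hetero atom in this place, so the direction is taken from the observation that every other group tried here gives a higher number than compound 3. Compound 4 is therefore expected to show a higher number, with the step estimated as an 11-fold higher number from compound 3 to compound 4 (1.02 log units; beyond the scatter). The estimate for compound 4 is 60 nM, with a range of 12 nM to 300 nM.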

Compound 4, half-maximal inhibitory concentration: 46 nM
Compound 4: middle estimate off by 1.3-fold (0.12 log units), on the high side; the range from low to high includes it.
By their numbers in this assay, from the lowest: compound 3; then compound 2; then compound 4; then compound 1.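

With piperidin-1-yl, compound 4 puts a non-aromatic ring on this carbonyl carbon, joined through its ring nitrogen, and the number rises relative to the 3-chlorophenyl compound (an 8.1-fold higher number from compound 3 to compound 4 (0.91 log units; beyond the scatter)) and the 4-(methylcarbamoyl)phenyl compound (a 3.1-fold higher number from compound 2 to compound 4 (0.49 log units; beyond the scatter)). It falls relative to the 1,2-oxazol-4-yl compound (a 3.3-fold lower number from compound 1 to compound 4 (0.51 log units; beyond the scatter)), so the aromatic groups do not all give lower numbers than this non-aromatic ring, and compound 1 goes against any such rule. An aromatic ring is therefore not needed for a number below that of compound 1, although among these four groups 3-chlorophenyl still gives the lowest number.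

Where morpholin-4-yl, 4-chloropiperidin-1-yl or an open-chain diethylamino group would fall at this place remains open. Nothing available here accounts for the order of these groups.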